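Swapping a Fluorophenyl for a Pyrazole on a Weak Inhibitor

A few compounds are considered here, and "the series" means these few. Any claim that something is new, unique, unknown or untested is made for them only; others in the source may bear on it.

Compound 1 `NC[C@@H]1CCN(c2ccc3c(=O)c(C(=O)O)cn(Cc4ccc(-n5cccn5)cc4)c3c2)C1`: 61000 nM
Compound 2 `NC[C@@H]1CCN(c2cc3c(cc2F)c(=O)c(C(=O)O)cn3Cc2ccc(-c3ccc(F)cc3)cc2)C1`: 69600 nM

Both compounds were tested in an assay on isolated protein for inhibition of DNA topoisomerase 1 (Homo sapiens), with a stated time of 15 min; on this read-out higher numbers stand for weaker inhibition and lower numbers for stronger inhibition. In this assay compound 1 gives 61000 nM, and compound 2 gives 69600 nM. Compound 2 has the highest of the two numbers, but the gap to compound 1 lies within the scatter, so the two values read as alike, and both stand for weak inhibition.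

Compound 3 `NC[C@@H]1CCN(c2cc3c(cc2F)c(=O)c(C(=O)O)cn3Cc2ccc(-n3cccn3)cc2)C1` has not yet been measured. It arises from compound 2 by a single change: 1H-pyrazol-1-yl in place of 4-fluorophenyl on an aromatic carbon. Within the data shown here, no step between measured compounds covers this change. Compound 1 also carries the 1H-pyrazol-1-yl group and gives 61000 nM, a value that sits close to compound 2. On this basis the step from compound 2 to compound 3 is expected to be small, with no direction beyond the scatter, a 1.2-fold lower number from compound 2 to compound 3 (0.06 log units; within the scatter). Compound 3 is therefore estimated at 60000 nM, within a range from 25000 nM to 150000 nM.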

Compound 3, half-maximal inhibitory concentration: 91600 nM
Compound 3: middle estimate off by 1.5-fold (0.18 log units), on the low side; measured number inside the range.
By their numbers in this assay, from the lowest: compounds 1, 2 and 3 (each within the scatter of the next).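

In this assay, putting 1H-pyrazol-1-yl in place of 4-fluorophenyl gives a 1.3-fold higher number from compound 2 to compound 3 (0.12 log units; within the scatter). At this aromatic carbon, para to a large group, a five-membered aromatic ring with hetero atoms can therefore take the place of a six-membered aromatic ring of carbon only without shifting the read-out beyond the scatter. With the 1H-pyrazol-1-yl group held in place, fluoro in place of hydrogen on an aromatic carbon gives a 1.5-fold higher number from compound 1 to compound 3 (0.18 log units; within the scatter), so this second change also stays within the scatter, and no measurement shown here bears on what lies behind these small steps.

As far as these compounds go, whether a different group at this position, such as a carboxylic acid, an amine or a longer chain, would move the number beyond the scatter remains open. Also open, from the compounds shown here alone, is whether any change can turn the weak inhibition seen here into strong inhibition.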